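Two Close Values and a Thiazolyl Swap

The source may hold more compounds than are shown below. What is called first, only, known or untested is meant among the compounds shown, and "the series" means these compounds.

Measured in a functional assay on U-937 cells (Homo sapiens) for cytotoxicity, read by MTT assay, with a stated time of 3 days; on this read-out lower numbers stand for stronger inhibition and higher numbers for weaker inhibition:
Compound 1 `N#Cc1c(NN)nc(SCc2nc3ccccc3[nH]2)nc1-c1ccccc1`: 3.9 nM
Compound 2 `N#Cc1c(Nc2ccccn2)nc(SCc2nc3ccccc3[nH]2)nc1-c1ccccc1`: 2.55 nM

For the measured compounds named here, compound 2 stands with the only other measured compound, inside the scatter. Compound 3 `N#Cc1c(Nc2nccs2)nc(SCc2nc3ccccc3[nH]2)nc1-c1ccccc1` differs from it by 1,3-thiazol-2-yl in place of pyridin-2-yl on a nitrogen on an aromatic ring, with 1,3-thiazol-2-yl in place of pyridin-2-yl on a nitrogen on an aromatic ring. Going by the values given here, one measured step bears on this place, a 1.5-fold lower number from compound 1 to compound 2 (0.18 log units; within the scatter), where pyridin-2-yl replaced amino. That single step gives no ground for expecting a change beyond the scatter in this assay. The expected step is a 1.2-fold higher number from compound 2 to compound 3 (0.07 log units; within the scatter). Compound 3 is estimated at 3 nM, with an expected range of 1.2 nM to 7.5 nM.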

Compound 3, half-maximal inhibitory concentration: 3.8 nM
The estimate for compound 3 lay 1.3-fold (0.10 log units) below the measured number, within the range that was stated.
By their numbers in this assay, from the lowest: compounds 2, 3 and 1 (each within the scatter of the next).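

In this assay, a five-membered aromatic ring on this nitrogen reads no differently from a six-membered one, with a 1.5-fold higher number from compound 2 to compound 3 (0.17 log units; within the scatter) for 1,3-thiazol-2-yl in place of pyridin-2-yl. With 1,3-thiazol-2-yl in place of amino there is a 1.0-fold lower number from compound 1 to compound 3 (0.01 log units; within the scatter), so a second aromatic ring has now been set against amino, and all three compounds lie within the scatter of one another. Nothing shown accounts for this flat result. On these data alone, whether a benzyl group or a longer alkyl chain on this nitrogen would move the number beyond the scatter remains open.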